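A Smaller Amide Group and Its Expected Lipophilicity

A few compounds are considered here, and "the series" means these few. Any claim that something is new, unique, unknown or untested is made for them only; others in the source may bear on it.

Among the measured compounds shown here, in a physicochemical assay for lipophilicity, read by HPLC, at pH 2 (a lower number here means a more polar compound, a higher number a more lipophilic compound), compound 2 `O=C(O)c1cnn(-c2cccc(-c3cccc(C(=O)N4CCCC5(CCCC5)C4)c3F)c2)c1C1CC1` gives 3.7, the higher of the two numbers so far, while compound 1 `CN(CC1CC1)C(=O)c1cccc(-c2cccc(-n3ncc(C(=O)O)c3C3CC3)c2)c1F` gives 2.2. Compound 3 `O=C(O)c1cnn(-c2cccc(-c3cccc(C(=O)N(CC4CC4)CC4CC4)c3F)c2)c1C1CC1` remains unmeasured and differs at one place: a group of 9 heavy atoms (8 carbon, 1 nitrogen; 2 three-membered non-aromatic rings of carbon only) in place of a group of 10 heavy atoms (9 carbon, 1 nitrogen; one five-membered non-aromatic ring of carbon only, one six-membered non-aromatic ring with 1 hetero atom), on a carbonyl carbon. For the measured compounds named here, one measured step bears on this change, at the same carbonyl carbon: a number 1.50 log units higher from compound 1 to compound 2 (beyond the scatter), a large one. The group in compound 3 lies between those of the two measured compounds in size, but much closer to that of compound 2, so a modest fall in this assay is expected. The estimated change is a number 0.50 log units lower from compound 2 to compound 3 (beyond the scatter). For compound 3 the expected value is 3.2, with an estimated range of 2.7 to 3.7.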

Compound 3, distribution coefficient: 3.5
Compound 3: the middle estimate sits 0.30 log units below what was measured; the measured number falls inside the stated range.
By their numbers in this assay, from the lowest: compound 1; then compounds 3 and 2 (each within the scatter of the next).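

In this assay, bis(cyclopropylmethyl)amino on this carbonyl carbon reads the same as the group it replaces, within the scatter (a number 0.20 log units lower from compound 2 to compound 3 (within the scatter)). Cyclopropyl in place of hydrogen on the saturated chain carbon bound to the amide-type nitrogen is by contrast a large step (a number 1.30 log units higher from compound 1 to compound 3 (beyond the scatter)). No measurement to hand gives a reason for either step.

The compounds shown leave open how this number would respond to a hydroxyl or an amine on the cyclopropylmethyl chains. They also leave open whether a longer chain, such as butyl, would read like cyclopropylmethyl.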